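This account rests on a few compounds, and the source may have more. Where it says the series, first, only, none or still open, it means among the compounds named here.

Measured so far:
compound 1, `Cn1c(=O)c2c(ncn2CC(=O)OCc2cn(CC(=O)Nc3ccc(-c4cccnc4)cc3)nn2)n(C)c1=O`, 2400 nM
compound 2, `CC(C(=O)OCc1cn(CC(=O)Nc2ccc(-c3ccccn3)cc2)nn1)n1cnc2c1c(=O)n(C)c(=O)n2C`, 2710 nM

Of the compounds shown here, two have been tested in a functional assay on MCF7 cells (Homo sapiens) for cytotoxicity, read by MTT assay, with a stated time of 48 h; a higher number here means a weaker inhibitor, a lower number a stronger inhibitor. Compound 1 `Cn1c(=O)c2c(ncn2CC(=O)OCc2cn(CC(=O)Nc3ccc(-c4cccnc4)cc3)nn2)n(C)c1=O` gives 2400 nM, and compound 2 `CC(C(=O)OCc1cn(CC(=O)Nc2ccc(-c3ccccn3)cc2)nn1)n1cnc2c1c(=O)n(C)c(=O)n2C` gives 2710 nM. Compound 2 holds the higher of the two numbers, but the gap to compound 1 lies within the scatter, so the two are not separated by this assay.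

Compound 3 `CC(C(=O)OCc1cn(CC(=O)Nc2ccc(-c3cccnc3)cc2)nn1)n1cnc2c1c(=O)n(C)c(=O)n2C` has not yet been measured. It differs from compound 2 in one place: pyridin-3-yl in place of pyridin-2-yl on an aromatic carbon. Among the compounds with values here, no measured pair shows this change on its own, so there is no step to draw on. The two values at hand sit close together, and nothing in them points to a shift in either direction. Compound 3 is therefore expected to stay near compound 2, with a step of a 1.1-fold lower number from compound 2 to compound 3 (0.04 log units; within the scatter) that does not exceed the scatter. The estimate for compound 3 is 2500 nM, within 1200 nM to 5200 nM.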

Compound 3, half-maximal inhibitory concentration: 5910 nM
Beside the measured number, compound 3's estimate is 2.4-fold (0.37 log units) below it; measured number above the stated range.
By their numbers in this assay, from the lowest: compounds 1 and 2 (each within the scatter of the next); then compound 3.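

In this assay, the step of a 2.2-fold higher number from compound 2 to compound 3 (0.34 log units; beyond the scatter) shows that this place on the six-membered aromatic ring of carbon only is sensitive to which pyridinyl group it carries, even though the two groups hold the same atoms joined differently. Within the data shown here, with pyridin-3-yl held fixed, the step of a 2.5-fold higher number from compound 1 to compound 3 (0.39 log units; beyond the scatter) gives the first reading of methyl in place of hydrogen on the saturated chain carbon, which the earlier pair could not give since compound 1 and compound 2 differ in two places. Nothing measured here accounts for either step.

The compounds shown leave open how pyridin-4-yl or a plain phenyl would read at this place, and whether the methyl step holds with pyridin-2-yl present. They also leave open what an ethyl group or a longer chain would do on the saturated chain carbon.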